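Chloro on the pendant phenyl of compound 3

A few compounds are considered here, and "the series" means these few. Any claim that something is new, unique, unknown or untested is made for them only; others in the source may bear on it.

The series is read in a functional assay on DU-145 cells (Homo sapiens) for cytotoxicity, read by MTT assay, with a stated time of 48 h; a lower number here means a stronger inhibitor, a higher number a weaker inhibitor. Compound 1 `CCOC(=O)c1c(-c2c(Cl)c3ccccc3oc2=O)nn(-c2cccc(Cl)c2)c1C(=O)OCC` gives 24000 nM. Within the data shown here, compound 2 `CCOC(=O)c1c(-c2c(Cl)c3cc(C)ccc3oc2=O)nn(-c2cccc(Cl)c2)c1C(=O)OCC` gives 156000 nM; the one single-point step measured so far, a 6.5-fold higher number from compound 1 to compound 2 (0.81 log units; beyond the scatter), concerns a methyl on the fused ring rather than the pendant phenyl. Compound 3 `CCOC(=O)c1c(-c2cc3ccccc3oc2=O)nn(-c2ccccc2)c1C(=O)OCC` gives 57000 nM, the second highest of the three numbers, beyond the scatter from both compound 1 and compound 2.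

Compound 4 `CCOC(=O)c1c(-c2cc3ccccc3oc2=O)nn(-c2ccc(Cl)cc2)c1C(=O)OCC` differs from compound 3 by chloro in place of hydrogen on an aromatic carbon. Among the measured compounds shown here, no measured step touches the pendant phenyl, so nothing sets a size for this change; the only step available, a 6.5-fold higher number from compound 1 to compound 2 (0.81 log units; beyond the scatter), is modest and sits on another ring. The expectation is therefore no step beyond the scatter in this assay, with wide uncertainty in both directions. The change from compound 3 is estimated as a 1.0-fold lower number from compound 3 to compound 4 (0.02 log units; within the scatter). Compound 4 is expected to give about 55000 nM, within a range from 18000 nM to 170000 nM.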

Compound 4, half-maximal inhibitory concentration: 26000 nM
Compound 4: the middle estimate sits 2.1-fold (0.33 log units) above what was measured; measured number inside the range.
By their numbers in this assay, from the lowest: compounds 1 and 4 (each within the scatter of the next); then compound 3; then compound 2.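

The pendant phenyl now has its first measured step: in this assay, phenyl to 4-chlorophenyl gives a 2.2-fold lower number from compound 3 to compound 4 (0.34 log units; beyond the scatter), so a single chlorine atom at this position is enough to move the number beyond the scatter. The step is modest and runs the opposite way to the methyl step, a 6.5-fold higher number from compound 1 to compound 2 (0.81 log units; beyond the scatter), although that is a different group at a different place on a different parent, so the two give no shared trend. Nothing measured here accounts for the shift at this position.

On these data alone, whether a fluoro, a methoxy or a carboxylic acid in the same place would move the number as chloro does stays open. Also open, as far as these compounds go, is whether chloro elsewhere on this six-membered ring would give a step of similar size on the parent of compound 3.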